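Cytotoxicity series: ethoxycarbonyl in place of phenyl

The source may hold more compounds than are shown below. What is called first, only, known or untested is meant among the compounds shown, and "the series" means these compounds.

Measured compounds, in a functional assay on B16 cells (Mus musculus) for cytotoxicity, read by MTT assay, with a stated time of 48 h; a higher number here means a weaker inhibitor, a lower number a stronger inhibitor:
compound 1 `C#Cc1cccc(NC(=O)c2cn(Cc3ccccc3)nn2)c1` gives 14500 nM
compound 2 `C#Cc1cccc(NC(=O)c2cn(CC(=O)OCC)nn2)c1` gives 91000 nM
compound 3 `O=C(NCc1cn(Cc2ccccc2)nn1)c1cn(Cc2ccccc2)nn1` gives 300 nM

Compound 3 sits lowest of the three in this assay; the gaps from compound 1 and from compound 2 to it both lie beyond the scatter, so compound 3 is the strongest inhibitor measured so far. Compound 1 and compound 3 differ in more than one place; the difference between the two cores is not broken down here.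

Within the core of compound 1, compound 2 differs from compound 1 by ethoxycarbonyl in place of phenyl on a saturated chain carbon bound to an aromatic nitrogen. The step from this change was a 6.3-fold higher number from compound 1 to compound 2 (0.80 log units; beyond the scatter), a weakening.

Compound 4 `CCOC(=O)Cn1cc(CNC(=O)c2cn(Cc3ccccc3)nn2)nn1` has not yet been measured in this assay. It differs from compound 3 by ethoxycarbonyl in place of phenyl on a saturated chain carbon bound to an aromatic nitrogen. The place is the same in words as for the earlier pair, so this is the same change, now carried out on the core of compound 3 rather than on the core of compound 1. Only one earlier instance of the change exists among these compounds, so the expectation rests on a single pair and on a different core.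

The step from compound 3 to compound 4 is expected to be a 6.3-fold higher number from compound 3 to compound 4 (0.80 log units; beyond the scatter) in this assay, because the only other occurrence of this change read a 6.3-fold higher number from compound 1 to compound 2 (0.80 log units; beyond the scatter). Compound 4 is estimated at 1900 nM in this assay, with a likely span from 600 nM to 6000 nM, starting from the value of compound 3, 300 nM.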

Compound 4, half-maximal inhibitory concentration: 35000 nM
Estimate against measurement, compound 4: 18-fold (1.27 log units) below, outside the stated range (above it).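

On the core of compound 3, ethoxycarbonyl in place of phenyl on a saturated chain carbon bound to an aromatic nitrogen reads a 120-fold higher number from compound 3 to compound 4 (2.07 log units; beyond the scatter) in this assay, a large weakening in the same direction as the earlier step. Across these two pairs the direction of the change carries from one core to the other, but its size does not: the same change on two cores in this assay, a 6.3-fold higher number (0.80 log units; beyond the scatter) from compound 1 to compound 2 and a 120-fold higher number (2.07 log units; beyond the scatter) from compound 3 to compound 4, 19-fold (1.27 log units) apart, beyond the scatter of two such steps
Two pairs do not show what sets the size of the step, and they give no basis for a size on any further core, so the step on one of these cores is a poor guide to its size on the other.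

As far as these compounds go, both pairs are the same exchange of benzyl for (ethoxycarbonyl)methyl, so it remains open whether a carboxylic acid or a primary amide in place of the ethyl ester, or a longer chain carrying the ester, would follow the step on the core of compound 1 or the one on the core of compound 3. Compound 4 also keeps one of the two benzyl groups of compound 3, which leaves open how the same exchange reads on that remaining benzyl, alone or together with the first.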